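Adding a Second Hydroxyl to the Amide Side Chain

The source may report more compounds than this note shows. Statements on the series, on what has been measured and on what is new or still open speak of the compounds shown alone.

Compound 1 `Cc1nc2ccc(NCc3cccc(C(F)(F)F)c3)cc2n(CCNC(=O)[C@@H](C)O)c1=O` is measured in an assay for inhibition of acyl-CoA desaturase 1 (Rattus norvegicus), using microsomes (a lower number here means a stronger inhibitor, a higher number a weaker inhibitor), where compound 1 gives 3900 nM, the highest of the three numbers here. Compound 2 `CC(C)c1nc2ccc(NCc3cccc(C(F)(F)F)c3)cc2n(CCNC(=O)CO)c1=O` gives 2800 nM, within the scatter of compound 1, while compound 3 `CC1Oc2ccc(NCc3ccc(Cl)c(Cl)c3)cc2N(CCNC(=O)CO)C1=O` gives 80 nM, far stronger and beyond the scatter. Compound 4 `Cc1nc2ccc(NCc3cccc(C(F)(F)F)c3)cc2n(CCNC(=O)C(O)CO)c1=O` differs from compound 1 at one place: 1,2-dihydroxyethyl in place of 1-hydroxyethyl on a carbonyl carbon. For the measured compounds named here, the data hold no measured step of this exact kind. Compound 2 carries the related hydroxymethyl on the same carbonyl and sits within the scatter of compound 1, so only a small step is expected from compound 1 to compound 4, a 1.1-fold lower number from compound 1 to compound 4 (0.05 log units; within the scatter), none beyond the scatter. Compound 4 is therefore estimated at 3500 nM, in the range 1500 nM to 8000 nM.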

Compound 4, half-maximal inhibitory concentration: 268 nM
Compound 4: the middle estimate sits 13-fold (1.12 log units) above what was measured; measured number outside the range, below it.
By their numbers in this assay, from the lowest: compound 3; then compound 4; then compounds 2 and 1 (each within the scatter of the next).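

In this assay the swap of 1-hydroxyethyl for 1,2-dihydroxyethyl on the carbonyl carbon brings a 15-fold lower number from compound 1 to compound 4 (1.16 log units; beyond the scatter) and so shows that a small change at this position can matter greatly. The earlier compounds shown here held no single-place step that could show this. Nothing shown here accounts for the size of the step.

The change also removes the defined stereocentre of compound 1, and the compounds shown cannot separate that loss from the added hydroxyl. As far as these compounds go, whether a longer chain with further hydroxyls, an amine or a carboxylic acid would do as well here stays open.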